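The source may hold more compounds than are shown below. What is called first, only, known or untested is meant among the compounds shown, and "the series" means these compounds.

- Compound 1 `COc1cc(C(=O)/C=C\Nc2ccc(-c3nc4cc(OC)c(OC)c(OC)c4s3)cc2)c(Br)c(OC)c1OC`: 13600 nM
- Compound 2 `COc1ccc2nc(-c3ccc(N/C=C\C(=O)c4ccc(OC)c([N+](=O)[O-])c4)c(C)c3)sc2c1`: 13600 nM
- Compound 3 `COc1ccc2nc(-c3ccc(N/C=C\C(=O)c4cc(OC)c(OC)c([N+](=O)[O-])c4)cc3)sc2c1`: 21600 nM

In a functional assay on A549 cells (Homo sapiens) for antiproliferative activity, read by sulforhodamine B assay, with a stated time of 48 h (a higher number here means a weaker inhibitor, a lower number a stronger inhibitor), compound 1 gives 13600 nM, level with compound 2 at the digits shown. Compound 3 gives 21600 nM, which is within the usual scatter of repeated measurements, so the three values cannot be ranked.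

Compound 4 `COc1cc(C(=O)/C=C\Nc2ccc(-c3nc4cc(OC)c(OC)c(OC)c4s3)cc2C)c(Br)c(OC)c1OC` is compound 1 changed in one place: methyl in place of hydrogen on an aromatic carbon. It is a small edit, and the rest of the structure of compound 1 stays as it is.

Among the measured compounds shown here, no two measured compounds differ in only one place, so the data hold no direct measure of what this change does. The expectation therefore rests on compound 1 at 13600 nM, and no shift beyond the scatter is expected in this assay. The expected result is a 1.1-fold lower number from compound 1 to compound 4 (0.05 log units; within the scatter). For compound 4 the estimated value is 12000 nM, with an expected range of 5000 nM to 30000 nM.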

Compound 4, half-maximal inhibitory concentration: 10300 nM
Compound 4: the middle estimate sits 1.2-fold (0.07 log units) above what was measured; low and high end bracket the measured number.
By their numbers in this assay, from the lowest: compounds 4, 1, 2 and 3 (each within the scatter of the next, the first and the last beyond it).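

Methyl in place of hydrogen on this aromatic carbon gives a 1.3-fold lower number from compound 1 to compound 4 (0.12 log units; within the scatter) in this assay and provides the first direct reading of a single change in this set. Compound 1 and compound 4 cannot be ranked, so this position tolerates one added methyl here, with antiproliferative activity staying in the same range. Nothing available explains this result.

Among the compounds shown here, the reading covers only this one small group at this one carbon, on the core of compound 1. Going by these compounds, whether a longer chain such as propyl, an amine or a carboxylic acid at the same carbon would also leave the number within the scatter remains open, as does whether methyl behaves the same way on the cores of compound 2 and compound 3.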